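This account rests on a few compounds, and the source may have more. Where it says the series, first, only, none or still open, it means among the compounds named here.

Compound 1, `CC1(C)S[C@@H]2/C(=C\C(=O)c3cc(F)cc(F)c3)C(=O)N2[C@H]1C(=O)OC(c1ccccc1)c1ccccc1`, gives 17600 nM in a functional assay on OE19 cells (Homo sapiens) for cytotoxicity, read by MTT assay, with a stated time of 48 h (a higher number here means a weaker inhibitor, a lower number a stronger inhibitor), the lowest number among the three measured compounds. Compound 3, `CC1(C)[C@H](C(=O)OC(c2ccccc2)c2ccccc2)N2C(=O)/C(=C/C(=O)c3ccccc3)[C@H]2S1(=O)=O`, gives 53100 nM in this assay, and compound 2, `CC1(C)[C@H](C(=O)OC(c2ccccc2)c2ccccc2)N2C(=O)/C(=C/C(=O)c3ccc([N+](=O)[O-])cc3)[C@H]2[S+]1[O-]`, gives 92400 nM in this assay; both values lie beyond the scatter from that of compound 1, so compound 1 is the strongest inhibitor of the three. Each of these two differs from compound 1 in more than one place, so no single change can be read from the gaps between them.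

Compound 4, `CC1(C)S[C@@H]2/C(=C\C(=O)c3ccco3)C(=O)N2[C@H]1C(=O)OC(c1ccccc1)c1ccccc1`, differs from compound 1 in one place: furan-2-yl in place of 3,5-difluorophenyl on a carbonyl carbon. Going by the values given here, no pair of measured compounds shows what this kind of change does in this assay, so the expectation rests on the closeness of the two structures alone. The step from compound 1 to compound 4 is expected to be small, a 1.4-fold higher number from compound 1 to compound 4 (0.15 log units; within the scatter), leaning toward a somewhat higher number but possibly no larger than the scatter. Compound 4 is therefore estimated at 25000 nM in this assay, within a range of 9000 nM to 70000 nM.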

Compound 4, half-maximal inhibitory concentration: 54300 nM
Beside the measured number, compound 4's estimate is 2.2-fold (0.34 log units) below it; the measured number falls inside the stated range.
By their numbers in this assay, from the lowest: compound 1; then compounds 3, 4 and 2 (each within the scatter of the next).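

Going by these compounds alone, the swap of 3,5-difluorophenyl for furan-2-yl on a carbonyl carbon gives the first step in this assay that can be read from a single change: a 3.1-fold higher number from compound 1 to compound 4 (0.49 log units; beyond the scatter). It shows that the group on this carbonyl carbon can move the number beyond the scatter while the rest of compound 1 stays the same, and that this change goes toward weaker inhibition. Nothing available explains the step.

This one change replaces a six-membered carbon ring with a five-membered ring holding a hetero atom and also removes both fluorines, so the compounds shown cannot separate these differences. Also open, going by these compounds, is where a thiophen-2-yl or a 3,5-dichlorophenyl group on the same carbonyl carbon would fall in this assay.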